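This account rests on a few compounds, and the source may have more. Where it says the series, first, only, none or still open, it means among the compounds named here.

Measured compounds in the cytotoxicity series:

Compound 1 `COc1ccc(/C=C2\SC(=O)N(Cc3ccc(C(=O)O)cc3)C2=O)cc1`, 48000 nM
Compound 2 `O=C(O)c1ccc(CN2C(=O)S/C(=C\c3cccs3)C2=O)cc1`, 76000 nM
Compound 3 `Cn1cccc1/C=C1\SC(=O)N(Cc2ccc(C(=O)O)cc2)C1=O`, 70000 nM

All three numbers come from a functional assay on MCF7 cells (Homo sapiens) for cytotoxicity, read by MTT assay, with a stated time of 24 h; on this read-out lower numbers stand for stronger inhibition and higher numbers for weaker inhibition. On that read-out compound 3 sits within the scatter of both neighbours: the step of a 1.1-fold lower number from compound 2 to compound 3 (0.04 log units; within the scatter) is very small, and the step of a 1.5-fold higher number from compound 1 to compound 3 (0.16 log units; within the scatter) is likewise within the scatter, so the three compounds cannot be told apart on these data.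

Compound 4 `O=C(O)c1ccc(CN2C(=O)S/C(=C\c3ccco3)C2=O)cc1` keeps the shared core of compound 3 and differs in a single place: furan-2-yl in place of 1-methyl-1H-pyrrol-2-yl on a double-bonded chain carbon bound to a double-bonded ring carbon. Among the compounds with values here, the steps that bear on this change are those in which the group on the same position was swapped among the measured compounds: a 1.6-fold higher number from compound 1 to compound 2 (0.20 log units; within the scatter), a 1.5-fold higher number from compound 1 to compound 3 (0.16 log units; within the scatter) and a 1.1-fold lower number from compound 2 to compound 3 (0.04 log units; within the scatter). Within the data shown here, each of them stayed within the scatter, so exchanging one five-membered aromatic ring with one hetero atom for another at this position has so far produced no step that can be separated from measurement noise. Compound 4 is therefore expected to behave like compound 3, with a step of a 1.0-fold higher number from compound 3 to compound 4 (0.01 log units; within the scatter) in this assay, none beyond the scatter. In this assay compound 4 is estimated at 72000 nM, with a range from 35000 nM to 145000 nM.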

Compound 4, half-maximal inhibitory concentration: 90000 nM
Compound 4: the middle estimate sits 1.3-fold (0.10 log units) below what was measured, and the stated range covers the measured number.
By their numbers in this assay, from the lowest: compounds 1, 3, 2 and 4 (each within the scatter of the next).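

In this assay, furan-2-yl now joins thiophen-2-yl, 1-methyl-1H-pyrrol-2-yl and 4-methoxyphenyl on the double-bonded chain carbon bound to a double-bonded ring carbon, and the new compound cannot be told apart from any of the three: the steps read (a 1.3-fold higher number from compound 3 to compound 4 (0.11 log units; within the scatter)), (a 1.2-fold higher number from compound 2 to compound 4 (0.07 log units; within the scatter)) and (a 1.9-fold higher number from compound 1 to compound 4 (0.27 log units; within the scatter)). The earlier compounds had shown this only for three groups, so the flat picture at this position now also holds for a five-membered aromatic ring carrying oxygen as its hetero atom. Going from the 6 heavy atoms of 1-methyl-1H-pyrrol-2-yl to the 5 of furan-2-yl likewise produced no step that can be separated from measurement noise. No supporting evidence is available that bears on this result.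

From the compounds shown here alone, all four groups at this position are aromatic rings, so it remains open whether an amine or a longer chain there would move the number beyond the scatter. Going by these compounds, it also remains open whether replacing the carboxylic acid of the shared core, for example with an amide, would change the read-out at all.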